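The source may hold more compounds than are shown below. What is called first, only, known or untested is meant among the compounds shown, and "the series" means these compounds.

In an ADME assay (liver) for metabolic stability, with Liver microsome (Homo sapiens) as the target, using microsomes and NADPH, with a stated time of 30 min, tested at 1 uM (on this read-out higher numbers stand for fast clearance and lower numbers for slow clearance), compound 1 `COCC#Cc1cc(C(O)(C(F)(F)F)C(F)(F)F)cnc1N1CCN(S(=O)(=O)c2ccc(N)nc2)CC1` gives 15 mL.min-1.g-1, compound 2 `CS(=O)(=O)c1ccc(-c2cc(C(O)(C(F)(F)F)C(F)(F)F)cnc2N2CCN(S(=O)(=O)c3ccc(N)nc3)CC2)cc1` gives 32 mL.min-1.g-1 and compound 3 `Cc1ccc(-c2cc(C(O)(C(F)(F)F)C(F)(F)F)cnc2N2CCN(S(=O)(=O)c3ccc(N)nc3)CC2)cn1` gives 43 mL.min-1.g-1. Compound 3 thus sits level with compound 2 and clearly above compound 1. Replacing 3-methoxyprop-1-yn-1-yl with an aromatic ring gave modest rises: a 2.1-fold higher number from compound 1 to compound 2 (0.33 log units; beyond the scatter) and a 2.9-fold higher number from compound 1 to compound 3 (0.46 log units; beyond the scatter). Compound 4 `Nc1ccc(S(=O)(=O)N2CCN(c3ncc(C(O)(C(F)(F)F)C(F)(F)F)cc3-c3ccc4ocnc4c3)CC2)cn1` carries 1,3-benzoxazol-5-yl in place of 6-methylpyridin-3-yl on an aromatic carbon. For the measured compounds named here, the only measured exchange of one aromatic ring for another stayed within the scatter, a 1.3-fold higher number from compound 2 to compound 3 (0.13 log units; within the scatter), so no step beyond the scatter is expected here. The estimated change is a 1.1-fold lower number from compound 3 to compound 4 (0.05 log units; within the scatter). For compound 4 the expected value is 38 mL.min-1.g-1, with an estimated range of 18 mL.min-1.g-1 to 80 mL.min-1.g-1.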

Compound 4, intrinsic clearance in microsomes: < 14 mL.min-1.g-1
Compound 4 ended at the assay's limit (the forecaster's own chance of this, stated with the estimate: 3%); at least 2.7-fold (0.43 log units) between middle value and limit.
By their numbers in this assay, from the lowest: compound 1; then compounds 2 and 3 (each within the scatter of the next). At a limit, below all of these: compound 4.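

In this assay compound 4 gives a limit, not a number: the limit of < 14 mL.min-1.g-1 in this assay, at which 1 of the 4 values shown sits.
At this aromatic carbon, exchanging a single six-membered aromatic ring for 1,3-benzoxazol-5-yl moves the read-out beyond the scatter, with an at least 3.0-fold lower number from compound 3 to compound 4 (0.48 log units; beyond the scatter) and an at least 2.2-fold lower number from compound 2 to compound 4 (0.35 log units; beyond the scatter), whereas the exchange between the two single rings did not, with a 1.3-fold higher number from compound 2 to compound 3 (0.13 log units; within the scatter). The remaining step, an at least 1.0-fold lower number from compound 1 to compound 4 (0.02 log units; that floor lies within the scatter), cannot be read.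

From the compounds shown here alone, whether the lower clearance needs both rings of 1,3-benzoxazol-5-yl remains open. Also open, going by these compounds, is where a plain phenyl or a morpholine at this carbon would fall.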